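Moving One Methoxy Group Around a Phenyl Ring

The source may report more compounds than this note shows. Statements on the series, on what has been measured and on what is new or still open speak of the compounds shown alone.

In a functional assay on U-87MG ATCC cells for antiproliferative activity against U-87 MG (Homo sapiens), read by MTT assay, with a stated time of 48 h (a lower number here means a stronger inhibitor, a higher number a weaker inhibitor), compound 3 `COc1ccc(-c2nc(SCC(=O)c3sc(-c4ccc(Cl)cc4)nc3C)[nH]c(=O)c2C#N)cc1` gives 35500 nM. Compound 1 `Cc1nc(-c2ccc(Cl)cc2)sc1C(=O)CSc1nc(-c2ccccc2)c(C#N)c(=O)[nH]1` gives 27600 nM, which lies within the scatter of that number. Compound 2 `COc1ccc(-c2nc(C)c(C(=O)CSc3nc(-c4cccc(OC)c4)c(C#N)c(=O)[nH]3)s2)cc1` gives 15300 nM, lower than the number for compound 3 by more than the scatter.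

Compound 4 `COc1cccc(-c2nc(SCC(=O)c3sc(-c4ccc(Cl)cc4)nc3C)[nH]c(=O)c2C#N)c1` contains the same atoms as compound 3, joined differently: 3-methoxyphenyl in place of 4-methoxyphenyl on an aromatic carbon. The methoxy group simply sits at another point on the same phenyl ring, and that ring stays on an aromatic carbon ortho to a cyano group.

Going by the values given here, the only measured single change on this phenyl ring is a 1.3-fold higher number from compound 1 to compound 3 (0.11 log units; within the scatter), where methoxy replaces hydrogen. Adding the group there therefore made no difference that the measurements can resolve, which suggests that moving it may not do so either. Among the compounds with values here, compound 2 also carries the 3-methoxyphenyl group, but no measured pair isolates that group from other changes, so it offers only a weak hint towards a lower number.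

The expected change is small, within the scatter, and is estimated as a 1.4-fold lower number from compound 3 to compound 4 (0.14 log units; within the scatter). For compound 4 the estimated value is 26000 nM, with an expected range from 12000 nM to 52000 nM.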

Compound 4, half-maximal inhibitory concentration: 41000 nM
Compound 4: middle estimate off by 1.6-fold (0.20 log units), on the low side; the range from low to high includes it.
By their numbers in this assay, from the lowest: compounds 2, 1, 3 and 4 (each within the scatter of the next, the first and the last beyond it).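

In this assay, the switch to 3-methoxyphenyl gives a 1.2-fold higher number from compound 3 to compound 4 (0.06 log units; within the scatter), so the two placements of methoxy on this phenyl ring cannot be told apart. The plain phenyl ring is not separated from the 3-methoxyphenyl ring either, at a 1.5-fold higher number from compound 1 to compound 4 (0.17 log units; within the scatter), which means that with the chloro group held in place, neither methoxy placement can be told apart from having no methoxy at all. Going by these compounds alone, the one step to compound 4 that lies beyond the scatter comes from another place in the molecule, where chloro stands in place of methoxy on an aromatic carbon, giving a 2.7-fold higher number from compound 2 to compound 4 (0.43 log units; beyond the scatter), a modest step, while the 3-methoxyphenyl group stays the same.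

Nothing available here explains any of these steps. Going by these compounds, it remains open whether a group of another kind on this phenyl ring, such as an amine or a carboxylic acid, would shift the number beyond the scatter, and whether the step between methoxy and chloro would hold with 4-methoxyphenyl or plain phenyl in place of 3-methoxyphenyl.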